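The compounds below may be only part of what the source reports. "The series", "measured", "known", "first", "only" and "open" are said of these compounds alone.

In an ADME assay on H9c2 cells (Rattus norvegicus) for cytotoxicity, read by resazurin assay, with a stated time of 72 h (on this read-out lower numbers stand for higher toxicity in this test and higher numbers for lower toxicity in this test), three compounds have been tested so far. Compound 1 `C/C(=N\Nc1nc(C)c(C)s1)c1ccc(Cl)c(Cl)c1` gives > 50000 nM, which is a limit of the assay and not a number. Compound 2 `C/C(=N\Nc1nc(-c2ccccc2)cs1)c1ccc(Cl)c(Cl)c1` gives > 50000 nM, again a limit of the assay and not a number. Compound 3 `C/C(=N\N=c1\scc(-c2ccccc2)n1-c1ccccc1)c1ccc(Cl)c(Cl)c1` gives > 50000 nM, which is also a limit. The whole picture is therefore (the limit of > 50000 nM in this assay, at which 3 of the 3 values shown sit), and compound 2 has no exact place and cannot be ranked against the other two.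

Compound 4 `C/C(=N\Nc1nc(-c2ccc(Br)cc2)cs1)c1ccc(Cl)c(Cl)c1` differs from compound 2 at one place: bromo in place of hydrogen on an aromatic carbon. In words, this is bromo in place of hydrogen on an aromatic carbon, turning phenyl into 4-bromophenyl. Among the compounds with values here, no pair of tested compounds shows what a change of this kind does in this assay, so the expectation is for no step beyond the usual scatter. That expectation rests on compound 2, whose > 50000 nM is a limit. The step expected is small, as a number no higher from compound 2 to compound 4 (the limit leaves the size open) shows, and it is only an estimate. For compound 4 the expected value is 50000 nM, with an estimated range from 20000 nM to 100000 nM.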

Compound 4, half-maximal cytotoxic concentration: > 50000 nM
Compound 4: only a limit was reported; the forecaster's own chance of this, stated with the estimate: 75%; the middle value sits exactly at the limit.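

In this assay compound 4 gives > 50000 nM, which is a limit of the assay and not a number. Within the data shown here, compound 2 also sits at a limit, so no step between compound 2 and compound 4 can be read. The compounds shown leave open how they rank against one another and what turning phenyl into 4-bromophenyl does to the read-out, because all their values stop at the same point: the limit of > 50000 nM in this assay, at which 4 of the 4 values shown sit.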